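A few compounds are considered here, and "the series" means these few. Any claim that something is new, unique, unknown or untested is made for them only; others in the source may bear on it.

In a functional assay on MDA-MB-231 cells (Homo sapiens) for inhibition, read by MTT assay, with a stated time of 72 h (on this read-out lower numbers stand for stronger inhibition and higher numbers for weaker inhibition), compound 2 `Nc1ncnc2c1c(-c1cnc3[nH]ccc3c1)nn2CCCCCC(=O)NO` gives > 100000 nM, which is a limit of the assay and not a number. This places it at the limit of > 100000 nM in this assay, at which 1 of the 2 values shown sits. Among the compounds with values here, the only measured value comes from compound 1 `CNC(=O)CCCCCCCn1nc(-c2cnc3[nH]ccc3c2)c2c(N)ncnc21`, which gives 15800 nM in this assay. Within the data shown here, the one measured step is an at least 6.3-fold higher number from compound 1 to compound 2 (0.80 log units; beyond the scatter), which lies beyond the scatter and puts hydroxycarbamoyl in place of 2-(methylcarbamoyl)ethyl on a saturated chain carbon. Compound 3 `Nc1ncnc2c1c(-c1cnc3[nH]ccc3c1)nn2CCCCCCCCCC(=O)NO` keeps the hydroxycarbamoyl end of compound 2 but has 4-(hydroxycarbamoyl)butyl in place of hydroxycarbamoyl on a saturated chain carbon, five bonds along the chain from an aromatic nitrogen. The measured step bears on this change only in part, as it alters chain length and end group together, so the two effects cannot be separated. Even so, the longer chain of compound 1 goes with a measurable 15800 nM, which suggests that lengthening the chain of compound 2 should move the number down. The expected change in this assay is therefore a clear drop, estimated as an at least 16-fold lower number from compound 2 to compound 3 (1.22 log units; beyond the scatter). Compound 3 is expected to give about 6000 nM, with an estimated range of 700 nM to 50000 nM.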

Compound 3, half-maximal inhibitory concentration: 10100 nM
Compound 3: middle estimate off by 1.7-fold (0.23 log units), on the low side; the measured number falls inside the stated range.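

In this assay, with the hydroxycarbamoyl end held fixed, 4-(hydroxycarbamoyl)butyl in place of hydroxycarbamoyl gives an at least 9.9-fold lower number from compound 2 to compound 3 (0.99 log units; beyond the scatter), so a change in chain length alone now moves the number, which the earlier step, with chain and end group altered together, could not show. On these data alone, the value of compound 2 is a limit of the assay and not a number, so the true size of this step stays unknown: the limit of > 100000 nM in this assay, at which 1 of the 3 values shown sits. The new comparison of end groups, 2-(hydroxycarbamoyl)ethyl in place of methylcarbamoyl, gives a 1.6-fold lower number from compound 1 to compound 3 (0.19 log units; within the scatter), which lies within the scatter, so in this assay the two ends are not told apart on chains of this length.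

The compounds shown leave open how the number behaves for a chain of intermediate length between those of compound 2 and compound 3, or for a longer chain than that of compound 3. They also leave open whether a carboxylic acid or an amine at the chain end would give a number different from those of the hydroxycarbamoyl and methylcarbamoyl ends.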